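The source may report more compounds than this note shows. Statements on the series, on what has been measured and on what is new or still open speak of the compounds shown alone.

Measured compounds:

Compound 1, `CN(C)C12CC(OC(=O)CN3CCCCC3)C(C(c3ccccc3)C1)C(c1ccccc1)C2`: in an ADME assay on L6 cells (Rattus norvegicus) for cytotoxicity (a lower number here means a stronger inhibitor, a higher number a weaker inhibitor), compound 1 gives 29300 nM.
Compound 2, `CN(C)C12CC(OC(=O)CCN3CCCC3)C(C(c3ccccc3)C1)C(c1ccccc1)C2`: in this assay compound 2 gives 26000 nM.

Within the data shown here, compound 2 has the lowest of the two numbers, but its only neighbour is compound 1, and the step of a 1.1-fold lower number from compound 1 to compound 2 (0.05 log units; within the scatter) lies within the scatter, so the two values cannot be told apart. Compound 3, `CN(C)C12CC(OC(=O)CCN3CCC(O)CC3)C(C(c3ccccc3)C1)C(c1ccccc1)C2`, has not yet been measured. It differs from compound 2 in one place: 4-hydroxypiperidin-1-yl in place of pyrrolidin-1-yl on a saturated chain carbon, two bonds along the chain from a carbonyl carbon.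

Among the measured compounds shown here, only one measured step bears on this change, the step of a 1.1-fold lower number from compound 1 to compound 2 (0.05 log units; within the scatter), which exchanged one saturated nitrogen ring for another on the same side chain and left the number where it was. For the measured compounds named here, the change to compound 3 again exchanges one such ring for another, now with a hydroxyl carried on the ring; nothing among the measured compounds shows what a hydroxyl on that ring does. On this basis the step of a 1.2-fold higher number from compound 2 to compound 3 (0.06 log units; within the scatter) is expected to stay within the scatter, with no clear direction. Compound 3 is therefore estimated at 30000 nM, in the range 12000 nM to 75000 nM.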

Compound 3, half-maximal inhibitory concentration: 89200 nM
Estimate against measurement, compound 3: 3.0-fold (0.47 log units) below; the whole stated range lies below it.
By their numbers in this assay, from the lowest: compounds 2 and 1 (each within the scatter of the next); then compound 3.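

In this assay, the saturated nitrogen ring on this side chain proved able to shift the number after all: 4-hydroxypiperidin-1-yl in place of pyrrolidin-1-yl gave a step beyond the scatter (a 3.4-fold higher number from compound 2 to compound 3 (0.54 log units; beyond the scatter)), and the comparison with the piperidin-1-yl side chain of compound 1 gave another (a 3.0-fold higher number from compound 1 to compound 3 (0.48 log units; beyond the scatter)). The earlier ring exchange had stayed within the scatter (a 1.1-fold lower number from compound 1 to compound 2 (0.05 log units; within the scatter)), so exchanging one such ring for another is not neutral in every case, and compound 3 stands apart from compounds 1 and 2, both steps pointing to a weaker inhibitor. No measurement offered here accounts for this shift.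

From the compounds shown here alone, what remains open is whether the higher number belongs to the hydroxyl itself, as each step to compound 3 also changes the ring or the chain; a 2-(piperidin-1-yl)ethyl side chain would compare directly with compound 3 and differ from it only by the hydroxyl. Whether another group on that ring, such as methoxy or an amine, would move the number in the same way is also unsettled.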